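This account rests on a few compounds, and the source may have more. Where it says the series, first, only, none or still open, it means among the compounds named here.

Measured compounds:
- Compound 1, `CC(C)(N)CC(=O)N[C@@H]1CCc2ccccc2N(Cc2ccc(-c3ccccc3-c3ncno3)cc2)C1=O`: 30 nM
- Compound 2, `CC(C)(N)CC(=O)N[C@@H]1CCc2ccccc2N(Cc2ccc(-c3ccccc3-c3nc[nH]n3)cc2)C1=O`: 90 nM
- Compound 3, `CC(C)(N)CC(=O)N[C@@H]1CCc2ccccc2N(Cc2ccc(-n3cccc3-c3nn[nH]n3)cc2)C1=O`: 275 nM

All three share one core and differ only in the two-ring group hanging from the benzyl arm. In a functional assay (Pituitary gland cell) with Rattus norvegicus as the target (on this read-out lower numbers stand for an effect already at smaller amounts and higher numbers for an effect only at larger amounts of compound), compound 3 gives the highest number of the three: it sits a 3.1-fold higher number from compound 2 to compound 3 (0.49 log units; beyond the scatter) and a 9.2-fold higher number from compound 1 to compound 3 (0.96 log units; beyond the scatter). Both of those steps replace a six-membered carbon ring carrying a small heterocycle with the pyrrole-tetrazole pair, so they show that changes in this outer ring pair move the read-out by modest amounts, and a 3.0-fold higher number from compound 1 to compound 2 (0.48 log units; beyond the scatter) shows the same for the heterocycle alone.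

Compound 4, `CC(C)(N)CC(=O)N[C@@H]1CCc2ccccc2N(Cc2ccc(-c3sccc3-c3nn[nH]n3)cc2)C1=O`, has not yet been measured. It differs from compound 3 by 3-(2H-tetrazol-5-yl)thiophen-2-yl in place of 2-(2H-tetrazol-5-yl)-1H-pyrrol-1-yl on an aromatic carbon. The tetrazole stays; only the five-membered ring that carries it changes, one hetero atom swapped for another. Among the measured compounds shown here, no measured step matches this exact exchange, so the direction is uncertain. Every change in this region so far moved this assay by a modest step, as in a 3.1-fold higher number from compound 2 to compound 3 (0.49 log units; beyond the scatter). A step of similar size is expected here too, with a slight lean toward a lower number since compound 3 is already the highest. The expected step is a 1.8-fold lower number from compound 3 to compound 4 (0.26 log units; within the scatter). Compound 4 is therefore estimated at 150 nM, ranging from 40 nM to 500 nM.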

Compound 4, half-maximal effective concentration: 140 nM
Compound 4: the middle estimate sits 1.1-fold (0.03 log units) above what was measured, and the stated range covers the measured number.
By their numbers in this assay, from the lowest: compound 1; then compounds 2, 4 and 3 (each within the scatter of the next, the first and the last beyond it).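

Replacing the pyrrole under the tetrazole with a thiophene gives a 2.0-fold lower number from compound 3 to compound 4 (0.29 log units; within the scatter) in this assay, so this exchange of one five-membered ring for another, with the tetrazole kept, cannot be told apart from no change at all. The step from the triazole-bearing phenyl group to the tetrazole-bearing thiophene is a 1.6-fold higher number from compound 2 to compound 4 (0.19 log units; within the scatter), so here a pair of five-membered rings cannot be told apart from the phenyl and triazole pair, although the pyrrole pair of compound 3 goes against any general rule, since its step from compound 2 lies beyond the scatter. The oxadiazole-bearing phenyl group remains apart, with a 4.7-fold higher number from compound 1 to compound 4 (0.67 log units; beyond the scatter), so the thiophene does not close the gap to the best number in this set. Nothing shown here gives a reason for any of these steps.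

The compounds shown leave open whether the tetrazole matters on the thiophene, as they include no thiophene carrying a 1,2,4-oxadiazole or a carboxylic acid instead. They also leave open how a furan would compare as the five-membered ring that carries the tetrazole.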